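A few compounds are considered here, and "the series" means these few. Any claim that something is new, unique, unknown or untested is made for them only; others in the source may bear on it.

In a physicochemical assay for lipophilicity, measured as octanol-water partition, with a stated time of 72 h (a higher number here means a more lipophilic compound, a lower number a more polar compound), compound 1 (`O=C(NO)Nc1ccccc1`) gives 0.41 and stands level, within the scatter, with compound 3 (`CCCCNC(=O)NO`), which gives 0.32 in the same test. Compound 2 (`CN(O)C(N)=O`) gives -0.46 and lies lower than compound 1, beyond the scatter. Compound 4 (`O=C(NO)Nc1ccc(Cl)cc1`) carries a single change from compound 1 (chloro in place of hydrogen on an aromatic carbon): chloro in place of hydrogen on an aromatic carbon. For the measured compounds named here, none of the measured compounds differ from each other in one place, so no measured step can guide the size. Resting on the structural change alone, a moderate rise in this assay is expected, beyond the scatter. The estimated step is a number 0.69 log units higher from compound 1 to compound 4 (beyond the scatter) and remains only an expectation. Compound 4 is estimated at 1.1 (expected range 0.8 to 1.4).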

Compound 4, partition coefficient: 1.39
Beside the measured number, compound 4's estimate is 0.29 log units below it; measured number inside the range.
By their numbers in this assay, from the lowest: compound 2; then compounds 3 and 1 (each within the scatter of the next); then compound 4.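

In this assay, for the compounds shown here, chloro in place of hydrogen on an aromatic carbon, para to a group of 5 heavy atoms, gives the first single-change step in this set, a number 0.98 log units higher from compound 1 to compound 4 (beyond the scatter), so this position clearly responds to this change. The earlier compounds shown here, which differ in more than one place, could not show this size. No measurement here explains the rise.

Going by these compounds, whether a methoxy group or a carboxylic acid in the same place would shift the number as far remains open. So does whether chloro elsewhere on this ring would give a similar step.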